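Replacing a phenoxy group with an amide on the biaryl tail

The source may hold more compounds than are shown below. What is called first, only, known or untested is meant among the compounds shown, and "the series" means these compounds.

Of the compounds shown here, three sharing one core have been measured in a functional assay for agonist activity at G protein-coupled receptor 88 (Homo sapiens), read by HTRF and cAMP accumulation; a lower number here means that less compound is needed, a higher number that more compound is needed for the effect. Compound 1 `CC[C@H](C)[C@H](N)CN(C(=O)[C@@H]1C[C@H]1c1ccccc1)c1ccc(-c2ccc(OC(C)C)cc2)cc1` gives 72 nM, compound 2 `CC[C@H](C)[C@H](N)CN(C(=O)[C@@H]1C[C@H]1c1ccccc1)c1ccc(-c2ccc(OC)cc2)cc1` gives 120 nM, and compound 3 `CC[C@H](C)[C@H](N)CN(C(=O)[C@@H]1C[C@H]1c1ccccc1)c1ccc(-c2ccc(Oc3ccccc3)cc2)cc1` gives 94 nM. Compound 3 thus stands second highest of the three numbers, but all three lie within the scatter of one another: the step of a 1.3-fold higher number from compound 1 to compound 3 (0.12 log units; within the scatter) and the step of a 1.3-fold lower number from compound 2 to compound 3 (0.11 log units; within the scatter) are both small, as is a 1.7-fold higher number from compound 1 to compound 2 (0.22 log units; within the scatter). Compound 4 `CC[C@H](C)[C@H](N)CN(C(=O)[C@@H]1C[C@H]1c1ccccc1)c1ccc(-c2ccc(C(=O)N(C)C)cc2)cc1` carries dimethylcarbamoyl in place of phenoxy on an aromatic carbon, the new group sitting para to a large group. The steps measured so far only exchange one oxygen-linked substituent for another at this aromatic carbon, and none of them moved the number beyond the scatter. The change to a dimethylcarbamoyl group is of a different kind and is not covered by any measured step, so the expectation rests on the tolerance already seen. Compound 4 is therefore estimated at 150 nM, with a range from 50 nM to 500 nM, the expected step being a 1.6-fold higher number from compound 3 to compound 4 (0.20 log units; within the scatter), with wide uncertainty in either direction.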

Compound 4, half-maximal effective concentration: 980 nM
Estimate against measurement, compound 4: 6.5-fold (0.82 log units) below, outside the stated range (above it).
By their numbers in this assay, from the lowest: compounds 1, 3 and 2 (each within the scatter of the next); then compound 4.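

In this assay, this aromatic carbon turns out not to accept every group: methoxy, isopropoxy and phenoxy stayed within the scatter of one another, whereas dimethylcarbamoyl brings a 10-fold higher number from compound 3 to compound 4 (1.02 log units; beyond the scatter), an 8.2-fold higher number from compound 2 to compound 4 (0.91 log units; beyond the scatter) and a 14-fold higher number from compound 1 to compound 4 (1.13 log units; beyond the scatter). All three steps lie beyond the scatter, so the tolerance seen among the oxygen-linked groups does not extend to this amide, whichever of them it replaces. Phenoxy and dimethylcarbamoyl have the same counts of hydrogen-bond donors and acceptors, so those counts do not separate them, and nothing measured here explains the rise.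

The compounds shown leave open whether the rise goes with the carbonyl attached directly to the aromatic carbon or with the two methyl groups on the amide nitrogen. A primary carboxamide, a methyl ketone or a carboxylic acid at the same carbon would help to separate these.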